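Shared core series: replacing the arylamine with dipropylamine

The source may hold more compounds than are shown below. What is called first, only, known or untested is meant among the compounds shown, and "the series" means these compounds.

Compound 1 `CCc1ccc(NC2=CC(=O)c3c(nc4n3[C@H]3OC[C@@H](O)[C@H]3OC4)C2=O)cc1` is measured in a functional assay on MGC-803 cells (Homo sapiens) for inhibition, read by sulforhodamine B assay (on this read-out higher numbers stand for weaker inhibition and lower numbers for stronger inhibition), where compound 1 gives 1110 nM. Compound 2 `O=C1C=C(Nc2ccc(Br)cc2)C(=O)c2c1nc1n2[C@H]2OC[C@@H](O)[C@H]2OC1` gives 1010 nM in this assay, and compound 3 `O=C1C=C(Nc2cccc(Cl)c2)C(=O)c2c1nc1n2[C@H]2OC[C@@H](O)[C@H]2OC1` gives 1770 nM. Compound 1 thus stands second highest of the three numbers, nearest to compound 2 and furthest from compound 3, but all three lie within the scatter of each other. Going by the values given here, the one single-point step so far, a 1.8-fold higher number from compound 2 to compound 3 (0.24 log units; within the scatter), exchanges one aromatic ring for another and is itself within the scatter.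

Compound 4 `CCCN(CCC)C1=CC(=O)c2c(nc3n2[C@H]2OC[C@@H](O)[C@H]2OC3)C1=O` is not yet measured. It differs from compound 1 by dipropylamino in place of (4-ethylphenyl)amino on a double-bonded ring carbon. Among the compounds with values here, no measured step bears on this change: every measured compound carries an aromatic amine, and the step from compound 2 to compound 3 only exchanges one such aryl group for another. The change from compound 1 to compound 4 removes the aromatic ring and the hydrogen-bond donor, so no direction can be drawn from the data, only a widened uncertainty. Compound 4 is therefore expected to give 1500 nM, with a range from 400 nM to 6000 nM; the expected step of a 1.4-fold higher number from compound 1 to compound 4 (0.13 log units; within the scatter) is set near no change but with wide bounds.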

Compound 4, half-maximal inhibitory concentration: > 16000 nM
Compound 4: a limit, no number (the forecaster's own chance of this, stated with the estimate: 10%); middle value at least 10-fold (1.02 log units) away from the limit.
By their numbers in this assay, from the lowest: compounds 2, 1 and 3 (each within the scatter of the next). At a limit, above all of these: compound 4.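

In this assay, going by these compounds alone, the group on the double-bonded ring carbon proves not to be freely exchangeable: dipropylamino in place of (4-ethylphenyl)amino gives an at least 14-fold higher number from compound 1 to compound 4 (1.15 log units; beyond the scatter), whereas the only earlier step, a 1.8-fold higher number from compound 2 to compound 3 (0.24 log units; within the scatter), merely exchanged one aryl group for another. The value for compound 4 is a limit of the assay, not a number: the limit of > 16000 nM in this assay, at which 1 of the 4 values shown sits. The closeness of compound 1, compound 2 and compound 3 therefore describes only these three arylamines and does not extend to this dialkylamine, in which the aromatic ring and the amine hydrogen are gone together.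

The compounds shown leave open which of these two losses accounts for the step. A propylamino group, which keeps the amine hydrogen without the ring, and a methyl(phenyl)amino group, which keeps the ring without that hydrogen, would separate them.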